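Working notes: propyl to methoxy on the aromatic ring

The source may report more compounds than this note shows. Statements on the series, on what has been measured and on what is new or still open speak of the compounds shown alone.

In a functional assay on MCF7 cells (Homo sapiens) for inhibition, read by MTT assay, with a stated time of 72 h (on this read-out lower numbers stand for stronger inhibition and higher numbers for weaker inhibition), compound 1 (`O=C(Nc1ccccc1)C1CCN(C/C=C/c2ccccc2)CC1`) gives 60200 nM and compound 2 (`CCc1ccc(NC(=O)C2CCN(C/C=C/c3ccccc3)CC2)cc1`) gives 20000 nM while compound 3 (`CCCc1ccc(NC(=O)C2CCN(C/C=C/c3ccccc3)CC2)cc1`) gives 9030 nM as the lowest of the three numbers. The next change leads to compound 4 (`COc1ccc(NC(=O)C2CCN(C/C=C/c3ccccc3)CC2)cc1`) and reads methoxy in place of propyl on an aromatic carbon in the form of methoxy in place of propyl on an aromatic carbon.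

Among the measured compounds shown here, three measured steps bear on this change, all modest and all beyond the scatter. Ethyl in place of hydrogen gives a 3.0-fold lower number from compound 1 to compound 2 (0.48 log units; beyond the scatter) and propyl in place of hydrogen gives a 6.7-fold lower number from compound 1 to compound 3 (0.82 log units; beyond the scatter) while methyl added to the ethyl chain gives a 2.2-fold lower number from compound 2 to compound 3 (0.35 log units; beyond the scatter) in the same direction. Among these three compounds, none goes against the fall in the number as the chain grows. For the measured compounds named here, no measured compound carries methoxy, so these steps bear on the change only indirectly. Propyl leaves in this change, so part of a 6.7-fold lower number from compound 1 to compound 3 (0.82 log units; beyond the scatter) is expected to be given back, with a modest move toward a higher number in this assay as the expected outcome. The expected step is a 2.4-fold higher number from compound 3 to compound 4 (0.39 log units; beyond the scatter) with wide uncertainty. Compound 4 is estimated at 22000 nM with an expected range from 8000 nM to 60000 nM in this read-out.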

Compound 4, half-maximal inhibitory concentration: > 100000 nM
Compound 4: only a limit was reported; the forecaster's own chance of this, stated with the estimate: 3%; middle value at least 4.5-fold (0.65 log units) from the limit.
By their numbers in this assay, from the lowest: compound 3; then compound 2; then compound 1. At a limit, above all of these: compound 4.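

Compound 4 stands at a limit of this assay, not at a number: the limit of > 100000 nM in this assay, at which 1 of the 4 values shown sits.

Ethyl and propyl had shown only a falling number as the chain grew, but this position also separates groups of similar count: with methoxy, the steps are an at least 11-fold higher number from compound 3 to compound 4 (1.04 log units; beyond the scatter) and an at least 5.0-fold higher number from compound 2 to compound 4 (0.69 log units; beyond the scatter). So the fall seen with the two alkyl chains does not carry over to every small group at this place. Methoxy in place of hydrogen gives an at least 1.6-fold higher number from compound 1 to compound 4 (0.22 log units; that floor lies within the scatter); that floor lies within the scatter, so methoxy is not shown to move the number beyond the scatter from the hydrogen compound, although the fall seen with ethyl and propyl does not appear.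

As far as these compounds go, how far the value of compound 4 lies past the limit stays open, so these steps are known only by their floors. Also open, from the compounds shown here alone, are whether the fall continues with a longer chain such as butyl, and where a hydroxy group, an amine or a chlorine atom at this place would fall, and these compounds give no cause for the methoxy result.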